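The source may hold more compounds than are shown below. What is called first, only, known or untested is meant among the compounds shown, and "the series" means these compounds.

Measured compounds:
- compound 1, `CNc1nc(NCc2ccc(NC(=O)c3ccc(F)cc3)cc2Cl)c2ccccc2n1`: 2300 nM in a functional assay on SW480 cells (Homo sapiens) for inhibition, read by luminescence and resazurin assay, with a stated time of 3 days; a lower number here means a stronger inhibitor, a higher number a weaker inhibitor
- compound 2, `Cc1ccc2nc(N(C)C)nc(NCc3ccc(C(=O)NC4CCN(Cc5ccc(F)cc5)CC4)cc3)c2c1`: 1100 nM

For the measured compounds named here, of the two numbers so far, compound 2 stands lowest in this assay; compound 1 gives the nearer and only other number, a higher one, and the gap between them lies beyond the usual scatter of such measurements.

Compound 3, `CCCNc1nc(NCc2ccc(C(=O)NC3CCN(Cc4ccc(F)cc4)CC3)cc2)c2cc(C)ccc2n1`, is not yet measured. It differs from compound 2 in one place: propylamino in place of dimethylamino on an aromatic carbon. Going by the values given here, no measured pair shows this change, so its effect is not known from the data here. The step is expected to be modest, with no direction that can be read from the numbers shown, and it may well fall within the scatter. Compound 3 is expected at 900 nM, with a range from 300 nM to 3000 nM in this assay. The expected step is a 1.2-fold lower number from compound 2 to compound 3 (0.09 log units; within the scatter).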

Compound 3, half-maximal inhibitory concentration: 1100 nM
For compound 3 the middle estimate is 1.2-fold (0.09 log units) below the measured one; low and high end bracket the measured number.
By their numbers in this assay, from the lowest: compounds 2 and 3 (each within the scatter of the next); then compound 1.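

In this assay, for the compounds shown here, putting propylamino in place of dimethylamino on the aromatic carbon between two ring nitrogen atoms gives no change at the digits printed from compound 2 to compound 3 (within the scatter), the first direct reading of a change at this position. Dimethylamino, with 0 hydrogen-bond donors and 3 heavy atoms, gives way to propylamino, with 1 hydrogen-bond donor and 4 heavy atoms, yet the two compounds cannot be told apart in this read-out. No measurement at hand offers a reason for this result.

On these data alone, whether a longer chain such as butylamino, or a carboxylic acid, would be accepted at this carbon remains open. Also open, as far as these compounds go, is whether the same swap would read the same way on the core of compound 1, which differs from compound 2 in more than one place.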